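Chloro in place of methyl on compound 3

The source may report more compounds than this note shows. Statements on the series, on what has been measured and on what is new or still open speak of the compounds shown alone.

In a functional assay on A549 cells (Homo sapiens) for antiproliferative activity, read by MTT assay, with a stated time of 72 h (a higher number here means a weaker inhibitor, a lower number a stronger inhibitor), compound 1 `CC(C)(C)OC(=O)N1CCN(C(=S)Sc2ccc(F)cc2)CC1` gives 1560 nM, compound 2 `CC(C)(C)OC(=O)N1CCN(C(=S)Sc2ccc(Br)cc2)CC1` gives 1820 nM and compound 3 `Cc1cccc(SC(=S)N2CCN(C(=O)OC(C)(C)C)CC2)c1` gives 914 nM. These three values lie within the scatter of one another, so compound 3 cannot be ranked apart from the other two.

The next structure, compound 4 `CC(C)(C)OC(=O)N1CCN(C(=S)Sc2cccc(Cl)c2)CC1`, is reached by chloro in place of methyl on an aromatic carbon, the same difference reading 3-methylphenyl to 3-chlorophenyl. Among the compounds with values here, no measured step makes this exchange directly. The closest evidence is the exchange of one halogen for another, a 1.2-fold higher number from compound 1 to compound 2 (0.07 log units; within the scatter), and the two replacements by 3-methylphenyl, a 1.7-fold lower number from compound 1 to compound 3 (0.23 log units; within the scatter) and a 2.0-fold lower number from compound 2 to compound 3 (0.30 log units; within the scatter). All three steps stay within the scatter, so no step beyond the scatter is expected here. The expected change is a 1.2-fold higher number from compound 3 to compound 4 (0.08 log units; within the scatter), which would also remain within the scatter. Compound 4 is estimated at 1100 nM, with an expected range of 500 nM to 2300 nM.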

Compound 4, half-maximal inhibitory concentration: 634 nM
Compound 4: middle estimate off by 1.7-fold (0.24 log units), on the high side, within the range that was stated.
By their numbers in this assay, from the lowest: compounds 4, 3, 1 and 2 (each within the scatter of the next, the first and the last beyond it).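

In this assay, chloro and methyl at this place, meta to a large group, cannot be told apart: the exchange gives a 1.4-fold lower number from compound 3 to compound 4 (0.16 log units; within the scatter). Within the data shown here, what is new is that the 3-chlorophenyl group yields the first steps beyond the scatter, both modest: a 2.9-fold lower number from compound 2 to compound 4 (0.46 log units; beyond the scatter) and a 2.5-fold lower number from compound 1 to compound 4 (0.39 log units; beyond the scatter). Each of these replaces a whole substituted phenyl group, so the identity of the halogen and its place on the ring change together, and nothing available accounts for the difference.

Going by these compounds, whether the separation follows the chlorine itself or its place on the ring stays open, a question that 4-chlorophenyl or 3-bromophenyl would address. Also open, on these data alone, is whether an amine or a carboxylic acid at the same place would stay within the scatter of methyl and chloro.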